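The compounds below may be only part of what the source reports. "The series", "measured", "known", "first", "only" and "open" are said of these compounds alone.

Compound 3 `Cc1cc(NC(=O)Nc2cccc(Cl)c2)c2ccccc2n1` stands lowest of the three compounds measured in a physicochemical assay for solubility, at pH 7.4 (a higher number here means a more soluble compound, a lower number a less soluble compound), where compound 3 gives 800 nM. Its nearest neighbour is compound 2 `Cc1ccc(NC(=O)Nc2cc(C)nc3ccccc23)cc1`, which in this assay gives 1300 nM; the step of a 1.6-fold lower number from compound 2 to compound 3 (0.21 log units; within the scatter) lies within the scatter. The furthest is compound 1 `COc1ccc(NC(=O)Nc2cc(C)nc3ccccc23)cc1`, which in this assay gives 19800 nM. Compound 4 `Cc1cc(NC(=O)Nc2ccc(O)cc2)c2ccccc2n1` has not yet been measured. It differs from compound 3 in one place: 4-hydroxyphenyl in place of 3-chlorophenyl on an amide-type nitrogen. Of the measured steps, a 1.6-fold lower number from compound 2 to compound 3 (0.21 log units; within the scatter) also sits on the amide-type nitrogen, but it swaps one group without hydrogen-bond donors or acceptors for another and stayed within the scatter. Within the data shown here, the step of a 15-fold lower number from compound 1 to compound 2 (1.18 log units; beyond the scatter) is the only one in which a group bearing a hydrogen-bond acceptor was exchanged, and it was large. Compound 4 brings in a hydrogen-bond donor and a hydrogen-bond acceptor that compound 3 lacks. Compound 4 is therefore expected to rise in this assay by a 10-fold higher number from compound 3 to compound 4 (1.00 log units; beyond the scatter). Compound 4 is estimated at 8000 nM, with a range from 2000 nM to 30000 nM.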

Compound 4, solubility: 100 nM
Compound 4: the middle estimate sits 80-fold (1.90 log units) above what was measured; measured number below the stated range.
By their numbers in this assay, from the lowest: compound 4; then compounds 3 and 2 (each within the scatter of the next); then compound 1.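

The amide-type nitrogen proves able to carry a change that moves the number in this assay beyond the scatter, with an 8.0-fold lower number from compound 3 to compound 4 (0.90 log units; beyond the scatter) standing against the earlier step there that stayed within it. The group on the aromatic carbon matters as well: a 13-fold lower number from compound 2 to compound 4 (1.11 log units; beyond the scatter) comes with hydroxy in place of methyl, so the direction seen on going from methoxy to methyl does not continue to hydroxy. Hydrogen in place of methyl on the oxygen, a single small edit, gives a 200-fold lower number from compound 1 to compound 4 (2.30 log units; beyond the scatter) and spans the whole range of the series, so methoxy and hydroxy are not interchangeable here.

Nothing measured here explains these steps. Open too, going by these compounds, is how an amine or a carboxylic acid on that aromatic carbon would stand against hydroxy and methoxy.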